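The compounds below may be only part of what the source reports. "The series", "measured", "known", "first", "only" and "open" are said of these compounds alone.

For the measured compounds named here, in an assay on C6 cells for antagonist activity at prostaglandin E2 receptor EP2 subtype (Homo sapiens), read by TR-FRET, with stated times of 10 min and 40 min, tested at 1 uM (on this read-out higher numbers stand for weaker inhibition and lower numbers for stronger inhibition), two compounds have numbers so far. Compound 1, `COc1ccc(/C=C/C(=O)NCCn2c(C(F)(F)F)cc3ccccc32)cc1`, gives 305 nM. Compound 2, `Cc1cc2ccccc2n1CCNC(=O)/C=C/c1ccc(OCCCN(C)C)cc1`, gives 74.6 nM, the lowest of the two, and compound 1 sits above it by a gap beyond the usual scatter. Compound 3, `COc1ccc(/C=C/C(=O)NCCn2c(C)cc3ccccc32)cc1`, has not yet been measured. It differs from compound 2 in one place: hydrogen in place of 2-(dimethylamino)ethyl on a saturated chain carbon bound to an oxygen on an aromatic ring. Through this change compound 3 comes to share the methoxy group of compound 1. Going by the values given here, no measured pair differs in only this place, so the size of the step cannot be read from the numbers; the expectation is a move toward a weaker number, because compound 1 with 305 nM also carries the methoxy group and sits higher. The step from compound 2 to compound 3 is expected to be a 2.7-fold higher number from compound 2 to compound 3 (0.43 log units; beyond the scatter). Compound 3 is therefore estimated at 200 nM, with a range from 70 nM to 600 nM.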

Compound 3, antagonist equilibrium constant: 16.5 nM
Compound 3: middle estimate off by 12-fold (1.08 log units), on the high side, outside the stated range (below it).
By their numbers in this assay, from the lowest: compound 3; then compound 2; then compound 1.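

Going from 3-(dimethylamino)propoxy to methoxy brings a 4.5-fold lower number from compound 2 to compound 3 (0.66 log units; beyond the scatter), so at this place the long chain ending in an amine is not needed for strong inhibition, and the small methoxy group does better with this core. The second single change, methyl in place of trifluoromethyl on an aromatic carbon, brings an 18-fold lower number from compound 1 to compound 3 (1.27 log units; beyond the scatter), a large step. Compound 1 and compound 2 differ in two places, so their gap alone could show neither effect, and only compound 3 separates them.

Nothing in the data gives a reason for either step. As far as these compounds go, whether an ethoxy group or a shorter chain ending in an amine would keep the strength of compound 3 stays open, as does whether a chlorine or an ethyl group could stand in for its methyl.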